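Shortening the chain toward the phenyl tail of compound 1

This account rests on a few compounds, and the source may have more. Where it says the series, first, only, none or still open, it means among the compounds named here.

Compound 1 `O=C(NCCCCCc1ccccc1)n1c(=O)oc2ccccc21` belongs to a small set of compounds that share a core and differ in the chain that carries an aromatic group. In an assay on HEK293 cells for inhibition of acid ceramidase (Homo sapiens), with a stated time of 10 min (a higher number here means a weaker inhibitor, a lower number a stronger inhibitor), compound 1 gives 54 nM. Compound 3 `O=C(NCCCCCCc1ccccc1)n1c(=O)oc2ccccc21` gives 51 nM and compound 2 `O=C(NCCCCc1ccc2ccccc2c1)n1c(=O)oc2ccccc21` gives 71 nM; compound 1 therefore stands second highest of the three numbers, with the others at a 1.1-fold lower number from compound 1 to compound 3 (0.02 log units; within the scatter) and a gap to compound 2 that stays within the scatter.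

Compound 4 `O=C(NCCCc1ccccc1)n1c(=O)oc2ccccc21` is the not yet measured partner of compound 1. The change is phenyl in place of phenethyl on a saturated chain carbon, three bonds along the chain from an amide-type nitrogen. Going by the values given here, the only measured step of the same kind runs the other way, lengthening rather than shortening the chain, and that step is a 1.1-fold lower number from compound 1 to compound 3 (0.02 log units; within the scatter). Among the compounds with values here, no measured step shortens the chain, so the expectation rests on the observation that adding a chain carbon changed nothing beyond the scatter, while removing two carbons is a larger move. A modest rise in the number, meaning a weaker inhibitor, is expected, stated as a 2.8-fold higher number from compound 1 to compound 4 (0.44 log units; beyond the scatter). The estimate for compound 4 in this assay is 150 nM, with a range from 50 nM to 500 nM.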

Compound 4, half-maximal inhibitory concentration: 55 nM
The estimate for compound 4 lay 2.7-fold (0.44 log units) above the measured number; low and high end bracket the measured number.
By their numbers in this assay, from the lowest: compounds 3, 1, 4 and 2 (each within the scatter of the next).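

In this assay the shortened chain gives a 1.0-fold higher number from compound 1 to compound 4 (0.01 log units; within the scatter), so putting phenyl in place of phenethyl on a saturated chain carbon, three bonds along the chain from an amide-type nitrogen, leaves the number within the scatter. Before this result the chain had been tested in one direction only, by the lengthening step, a 1.1-fold lower number from compound 1 to compound 3 (0.02 log units; within the scatter), and the shortening step now shows the same outcome in the opposite direction: around compound 1, neither change to the chain moves the number beyond the scatter, and nothing among compounds 1, 3 and 4 goes against this. No measurement at hand bears on why the number holds steady across these chains.

From the compounds shown here alone, how far this tolerance reaches remains open, since a much longer chain, or a still shorter one, could behave differently from compounds 1, 3 and 4. It is also unknown whether the number would hold with an amine or a carboxylic acid on the chain, or with a chlorine or a methoxy group on the phenyl ring.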